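Compound 1 to compound 4: a methyl step

The compounds below may be only part of what the source reports. "The series", "measured", "known", "first", "only" and "open" are said of these compounds alone.

Compound 1 `CC(C)Nc1nc(NCc2ccco2)c2ccccc2n1` anchors the series in a physicochemical assay for solubility, at pH 7.4; on this read-out lower numbers stand for lower solubility and higher numbers for higher solubility. Compound 1 reads >= 30000 nM, which is a limit. Compound 2 `CSCCNc1nc(NC(C)C)nc2ccccc12` reads <= 20000 nM, also a limit. Compound 3 `CC(C)Nc1nc(NCc2ccco2)c2c(Cl)cccc2n1` reads <= 10000 nM, again a limit. Compound 4 `Cc1ccc2c(NCc3ccco3)nc(NC(C)C)nc2c1` carries methyl in place of hydrogen on an aromatic carbon. The closest measured change is chloro in place of hydrogen on an aromatic carbon, giving an at least 3.0-fold lower number from compound 1 to compound 3 (0.47 log units; beyond the scatter). The side-chain change giving an at least 1.5-fold lower number from compound 1 to compound 2 (0.17 log units; that floor lies within the scatter) bears on it less. Going by compound 3 and an at least 3.0-fold lower number from compound 1 to compound 3 (0.47 log units; beyond the scatter), a modest fall in this assay is expected, though its size is uncertain. The expected step is an at least 2.0-fold lower number from compound 1 to compound 4 (0.30 log units; that floor lies within the scatter). For compound 4 the estimated value is 15000 nM, within an expected range of 5000 nM to 40000 nM.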

Compound 4, solubility: <= 20000 nM
Compound 4 gave a limit, no number (the forecaster's own chance of this, stated with the estimate: 60%); the middle value lies beyond the limit too.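

In this assay, methyl in place of hydrogen on an aromatic carbon, meta to a fused ring and para to a fused ring, gives an at least 1.5-fold lower number from compound 1 to compound 4 (0.17 log units; that floor lies within the scatter). Unlike the chloro step, an at least 3.0-fold lower number from compound 1 to compound 3 (0.47 log units; beyond the scatter), this floor does not clear the scatter. The value of compound 4 is a limit, so the step has a floor but no size, and this limit recurs in the series: the limit of <= 20000 nM in this assay, at which 2 of the 4 values shown sit.

From the compounds shown here alone, whether methyl at this place lowers the read-out beyond the scatter stays open. So does how an amine or a methoxy group on this aromatic carbon would read.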